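This account rests on a few compounds, and the source may have more. Where it says the series, first, only, none or still open, it means among the compounds named here.

Three compounds sharing one core, and differing in a single nitrogen substituent, have been tested in an ADME assay on MT4 cells (Homo sapiens) for cytotoxicity, read by MTT assay, with a stated time of 5 days; a higher number here means that more compound is tolerated, a lower number that less compound is tolerated. Compound 1 (`CCCC(CCC)Nc1cc(Oc2c(OC)cc3cc(C#N)ccc3c2OC)nc(Nc2ccc(C#N)cc2)n1`), with 1-propylbutyl, gives only the assay limit > 125000 nM and no number. Compound 2 (`COc1cc2cc(C#N)ccc2c(OC)c1Oc1cc(NC2CCC2)nc(Nc2ccc(C#N)cc2)n1`), with cyclobutyl, also gives only the limit > 125000 nM and no number. Among the compounds with values here, compound 3 (`COc1cc2cc(C#N)ccc2c(OC)c1Oc1cc(NCCCO)nc(Nc2ccc(C#N)cc2)n1`), with 3-hydroxypropyl, is the only one with a true number, at 23500 nM in this assay. Within the data shown here, two measured steps bear on what follows: an at least 5.3-fold lower number from compound 1 to compound 3 (0.72 log units; beyond the scatter) and an at least 5.3-fold lower number from compound 2 to compound 3 (0.72 log units; beyond the scatter) both bring in the hydroxy-bearing chain. Compound 4 (`COc1cc2cc(C#N)ccc2c(OC)c1Oc1cc(N2CCC(O)C2)nc(Nc2ccc(C#N)cc2)n1`) has 3-hydroxypyrrolidin-1-yl in place of (3-hydroxypropyl)amino on an aromatic carbon and so keeps a hydroxy group. Among the measured compounds shown here, no measured step tests this ring, so compound 3 at 23500 nM is the best guide, and no change beyond the scatter is expected. The estimate is a 1.3-fold higher number from compound 3 to compound 4 (0.11 log units; within the scatter) as the expected step. For compound 4 the expected value is 30000 nM, with an estimated range from 9000 nM to 90000 nM in this assay.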

Compound 4, half-maximal cytotoxic concentration: > 125000 nM
Compound 4 ended at the assay's limit (the forecaster's own chance of this, stated with the estimate: 15%); middle value at least 4.1-fold (0.61 log units) from the limit.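

Within the data shown here, until now, the only true number at this position belonged to the one open hydroxy-bearing chain, so the hydroxy group could not be separated from the chain that carries it. In this assay, 3-hydroxypyrrolidin-1-yl keeps the hydroxy group yet gives an at least 5.3-fold higher number from compound 3 to compound 4 (0.72 log units; beyond the scatter), so a hydroxy group on this substituent does not by itself go with the lower number. Compound 3 now stands alone, and the steps among compound 1, compound 2 and compound 4 cannot be read, with all three resting on one assay limit: the limit of > 125000 nM in this assay, at which 3 of the 4 values shown sit.

The limit also leaves unknown how far compound 4 lies from compound 3. Going by these compounds, whether a longer hydroxy-bearing chain, or an open chain ending in an amine or a carboxylic acid, would give a true number in this assay remains open.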